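Pyrimidinone series: cyclopropyl for ethyl on the side chain

The source may hold more compounds than are shown below. What is called first, only, known or untested is meant among the compounds shown, and "the series" means these compounds.

Measured so far:
- compound 1 `CC[C@H](COC)n1c(=O)c(C)nc2c(-c3ccc(Cl)cc3Cl)ncnc21`: 97 nM
- compound 2 `CCC(COC)n1c(=O)c(C)nc2c(-c3cc(F)c(OC)cc3Cl)ccnc21`: 2.1 nM
- compound 3 `CC[C@@H](C1CC1)n1c(=O)c(C)nc2c(-c3ccc(OC(F)F)cc3Cl)ccnc21`: 7.3 nM

In a functional assay for antagonist activity at corticotropin-releasing factor receptor 1 (Rattus norvegicus) (a higher number here means a weaker inhibitor, a lower number a stronger inhibitor), compound 2 gives the lowest of the three numbers. Compound 3 sits nearest to it, at a higher number that is beyond the scatter, and compound 1 sits furthest, with the largest gap of the set. Compound 3 carries a cyclopropyl on the side chain, but it also differs from compound 2 in the aryl part, so its value alone does not isolate the side chain.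

Compound 4 `COCC(C1CC1)n1c(=O)c(C)nc2c(-c3cc(F)c(OC)cc3Cl)ccnc21` keeps the aryl part of compound 2 and changes only the side chain: cyclopropyl in place of ethyl on a saturated chain carbon bound to an aromatic nitrogen and a saturated chain carbon. Within the data shown here, no measured pair shows this single change, so the size of the step is not established by the present numbers.

The expectation is for a step from compound 2 to compound 4 of a 1.4-fold higher number from compound 2 to compound 4 (0.15 log units; within the scatter), roughly neutral and not clearly beyond the scatter in either direction. The expected value for compound 4 in this assay is 3 nM, in a range from 1 nM to 9 nM.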

Compound 4, half-maximal inhibitory concentration: 1.5 nM
Beside the measured number, compound 4's estimate is 2.0-fold (0.30 log units) above it; the range from low to high includes it.
By their numbers in this assay, from the lowest: compounds 4 and 2 (each within the scatter of the next); then compound 3; then compound 1.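

In this assay, among these compounds, the replacement of ethyl by cyclopropyl on a saturated chain carbon bound to an aromatic nitrogen and a saturated chain carbon gives a 1.4-fold lower number from compound 2 to compound 4 (0.15 log units; within the scatter), the first reading of this single change with the aryl part held constant. The two values cannot be told apart, so at this position, with this aryl part, the three-membered ring and its additional carbon leave the number where it was, and the 1-cyclopropyl-2-methoxyethyl chain serves as well here as the 1-(methoxymethyl)propyl chain. Nothing at hand explains this equivalence, and the pair supports no statement about why the two chains read alike.

Still open, from the compounds shown here alone, is how far this carbon accepts other groups, such as a cyclobutyl ring, a longer chain like n-butyl, or an amine, and whether the same replacement reads alike with a different aryl part on the shared core. Going by these compounds, compound 2 and compound 4 are drawn without a defined configuration at this carbon, so how the separate mirror-image forms compare also remains open.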